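A few compounds are considered here, and "the series" means these few. Any claim that something is new, unique, unknown or untested is made for them only; others in the source may bear on it.

Compound 1, `Fc1ccc2nc(-c3ccccc3)nc(Nc3ccccc3)c2c1`, gives in a functional assay on MCF7 cells (Homo sapiens) for cytotoxicity, read by MTT assay, with a stated time of 48 h (on this read-out higher numbers stand for weaker inhibition and lower numbers for stronger inhibition), a value that is only a limit of the assay: > 50000 nM.
Compound 2, `Fc1cccc(Nc2nc(-c3cccc(F)c3)nc3ccc(F)cc23)c1`, gives in this assay a value of 48700 nM.
Compound 3, `Fc1cccc(-c2nc(Nc3ccccc3F)c3cc(F)ccc3n2)c1`, gives in this assay only a limit of the assay: > 50000 nM.

Among the measured compounds shown here, compound 3 therefore stands at the edge of what this assay can report, and the one measured step that reaches it, an at least 1.0-fold higher number from compound 2 to compound 3 (0.01 log units; that floor lies within the scatter), lies within the scatter. For the measured compounds named here, two of the three values shown sit at the same limit (the limit of > 50000 nM in this assay, at which 2 of the 3 values shown sit), so none of the measured compounds shows clear inhibition in this assay.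

Compound 4, `Fc1cccc(-c2nc(Nc3cccc(Br)c3)c3cc(F)ccc3n2)c1`, is the next compound to be measured. It differs from compound 3 in one place: 3-bromophenyl in place of 2-fluorophenyl on a nitrogen on an aromatic ring. Going by the values given here, no measured step puts a bromine-bearing ring at this nitrogen, and the only step at this nitrogen, the move from compound 2 to compound 3, did not leave the scatter. The expectation is therefore no step beyond the scatter, and the step from compound 3 to compound 4 is estimated as a number no higher from compound 3 to compound 4 (the limit leaves the size open). Compound 4 is expected to give about 50000 nM in this assay, within a range of 20000 nM to 120000 nM, most likely again as a limit rather than a number.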

Compound 4, half-maximal inhibitory concentration: > 50000 nM
Compound 4: a limit, no number; the forecaster's own chance of this, stated with the estimate: 70%; the middle value lies on the limit itself.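

Changing fluoro to bromo on an aromatic carbon of the ring on this nitrogen gives in this assay an at least 1.0-fold higher number from compound 2 to compound 4 (0.01 log units; that floor lies within the scatter), so this first change of halogen at the position shows no step beyond the scatter. The step between compound 3 and compound 4 cannot be read, as both values are limits of the assay. A larger halogen atom on this ring therefore brings no clear inhibition into view, and the series stays crowded at the top of the range: the limit of > 50000 nM in this assay, at which 3 of the 4 values shown sit.

All four compounds shown carry a plain phenyl ring or a phenyl ring bearing fluorine or bromine on this nitrogen, so it remains open whether a ring bearing a methoxy group, an amine or a carboxylic acid would give a number clearly lower than this limit. The compounds at the limit also cannot be ranked among themselves, which leaves open which of these rings, if any, comes closest to real inhibition in this assay.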